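The compounds below may be only part of what the source reports. "The series", "measured", "known", "first", "only" and "open" are said of these compounds alone.

In a functional assay on CUTLL1 cells (Homo sapiens) for inhibition, read by resazurin assay, with a stated time of 48 h, in the presence of a further agent that is not named here (a lower number here means that less compound is needed, a higher number that more compound is needed for the effect), three compounds have been measured so far, and none of them gives an exact number. Compound 1 `Nc1ncc(-c2ccncc2-c2ccccc2)c(C2CC2)n1` reads > 100000 nM, which is a limit of the assay and not a number. Compound 2 `CC(C)c1nc(N)ncc1-c1ccncc1` reads > 100000 nM, again a limit. Compound 3 `Cc1nc(N)ncc1-c1ccncc1` reads > 100000 nM, also a limit, so its standing is known only as that limit. Taken together, the measurements stand at the limit of > 100000 nM in this assay, at which 3 of the 3 values shown sit.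

Compound 4 `Nc1ncc(-c2ccncc2)cn1` has not yet been measured. It differs from compound 3 by a single change, hydrogen in place of methyl on an aromatic carbon. The closest measured comparison is also a swap on an aromatic carbon, methyl in place of isopropyl, and it appears as a step that the two limits leave unreadable from compound 2 to compound 3. That comparison offers no size or direction to carry forward. On this evidence, no shift beyond the usual scatter is expected in this assay, and a further reading at the same limit is the likeliest outcome. The expected change is a number no higher from compound 3 to compound 4 (the limit leaves the size open). For compound 4, the estimated value is 100000 nM, within an expected range from 30000 nM to 300000 nM.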

Compound 4, half-maximal effective concentration: > 100000 nM
Compound 4 was reported as a limit; the forecaster's own chance of this, stated with the estimate: 85%; the middle value sits exactly at the limit.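

In this assay, compound 4 is reported only as a limit and not as a number, so neither its step from compound 3 nor its step from compound 2 can be read. The compounds shown leave open which change to the shared core, if any, would give a reading away from the limit where they all stand: the limit of > 100000 nM in this assay, at which 4 of the 4 values shown sit.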